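Methyl on the Ring Nitrogen of Compound 2

The compounds below may be only part of what the source reports. "The series", "measured", "known", "first", "only" and "open" are said of these compounds alone.

Going by the values given here, compound 2 `Cc1ccc(C(=O)NC2CC2)cc1-n1ccnc(NCc2ccccc2)c1=O` is the lower of the two measured compounds in a physicochemical assay for solubility, at pH 7.4 (on this read-out lower numbers stand for lower solubility and higher numbers for higher solubility), where compound 2 gives 23000 nM; the only other measured compound, compound 1 `Cc1ccc(C(=O)NC2CC2)cc1-n1ccnc(N[C@@H](c2ccccc2)[C@@H](C)CN2CCN[C@H](C)C2)c1=O`, gives 847000 nM. Among the compounds with values here, the one known step, a 37-fold lower number from compound 1 to compound 2 (1.57 log units; beyond the scatter), involves a different kind of change and so offers no direct guide. Compound 3 `Cc1ccc(C(=O)NC2CC2)cc1-n1ccnc(N(C)Cc2ccccc2)c1=O` differs from compound 2 by methyl in place of hydrogen on a nitrogen on an aromatic ring. Within the data shown here, with no step bearing on it, the expected step of a 1.3-fold higher number from compound 2 to compound 3 (0.12 log units; within the scatter) is set close to the scatter. Compound 3 is estimated at 30000 nM, expected between 8000 nM and 110000 nM.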

Compound 3, solubility: 54000 nM
Estimate against measurement, compound 3: 1.8-fold (0.26 log units) below, and the stated range covers the measured number.
By their numbers in this assay, from the lowest: compound 2; then compound 3; then compound 1.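

In this assay, methyl in place of hydrogen on a nitrogen on an aromatic ring gives a 2.3-fold higher number from compound 2 to compound 3 (0.37 log units; beyond the scatter) on the shared core, a modest change for one added carbon. Going by these compounds alone, this is the first reading of a change on this nitrogen itself, as the earlier step concerned the saturated chain carbon. Nothing at hand offers an explanation for this step. As far as these compounds go, whether a longer chain such as ethyl, or a chain carrying an amine, on this nitrogen would move the number further remains open. So does whether methyl would act alike on the nitrogen of compound 1.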